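Replacing 1-carboxyethyl with carboxy(fluoro)methyl in compound 2

The source may report more compounds than this note shows. Statements on the series, on what has been measured and on what is new or still open speak of the compounds shown alone.

Measured so far in an ADME assay on the whole organism (Rattus norvegicus, strain Sprague-Dawley) for metabolic stability, read by LC-MS, at a dose of 10 mg/kg by the oral route; a higher number here means that the compound lasts longer, a lower number that the compound disappears faster:
- Compound 1 `COc1ccc(F)c([C@H]2CC[C@H](COc3cccc([C@@H](CC(=O)O)C4CC4)c3)CC2)c1`: 9.1 h
- Compound 2 `COc1ccc(F)c([C@H]2CC[C@H](COc3cccc([C@H](C4CC4)[C@H](C)C(=O)O)c3)CC2)c1`: 4.4 h

Compound 2, at 4.4 h, stands lowest of the two. Compound 3 `COc1ccc(F)c([C@H]2CC[C@H](COc3cccc([C@H](C4CC4)[C@@H](F)C(=O)O)c3)CC2)c1` differs from it by one change: carboxy(fluoro)methyl in place of 1-carboxyethyl on a saturated chain carbon bound to an aromatic carbon and a saturated ring carbon. Among the measured compounds shown here, the only measured step that bears on this is a 2.1-fold lower number from compound 1 to compound 2 (0.32 log units; beyond the scatter), a modest step beyond the scatter that came with methyl in place of hydrogen. For the measured compounds named here, no measured compound carries carboxy(fluoro)methyl, so this guide is weak. Compound 3 loses that methyl, so a modest rise is expected, with a 1.5-fold higher number from compound 2 to compound 3 (0.17 log units; within the scatter) as the estimated step. For compound 3 the estimated half-life in this assay is 6.5 h, with an expected range of 3 h to 13 h.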

Compound 3, half-life: 4.3 h
Beside the measured number, compound 3's estimate is 1.5-fold (0.18 log units) above it; measured number inside the range.
By their numbers in this assay, from the lowest: compounds 3 and 2 (each within the scatter of the next); then compound 1.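

In this assay, exchanging 1-carboxyethyl for carboxy(fluoro)methyl makes no difference beyond the scatter (a 1.0-fold lower number from compound 2 to compound 3 (0.01 log units; within the scatter)). Fluoro in place of hydrogen on the chain carbon bound to the carbonyl carbon gives a modest step (a 2.1-fold lower number from compound 1 to compound 3 (0.33 log units; beyond the scatter)), much like the one seen with methyl, so that step is not unique to methyl. Nothing available explains this result.

Going by these compounds, whether a larger group there, such as ethyl, or a hydroxyl would go with the same step stays open. So does the effect of the opposite arrangement at this stereocentre.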